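Isopropylamino to diethylamino on a sulfonyl sulfur

The source may hold more compounds than are shown below. What is called first, only, known or untested is meant among the compounds shown, and "the series" means these compounds.

In a functional assay on MIA PaCa-2 cells (Homo sapiens) for inhibition, read by MTT assay, with a stated time of 3 days (a lower number here means a stronger inhibitor, a higher number a weaker inhibitor), the measured compounds read as follows:
compound 1 `CCN(CC)S(=O)(=O)c1ccc(S(=O)(=O)N2CCC[C@@H](C(=O)N3CCN(c4nc(C(F)(F)F)no4)CC3)C2)cc1` gives 60 nM here
compound 2 `CC(C)c1noc(N2CCN(C(=O)[C@@H]3CCCN(S(=O)(=O)c4ccc(S(=O)(=O)NC5CC5)cc4)C3)CC2)n1` gives 300 nM here
compound 3 `CC(C)NS(=O)(=O)c1ccc(S(=O)(=O)N2CCC[C@@H](C(=O)N3CCN(c4nc(C(C)C)no4)CC3)C2)cc1` gives 200 nM here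

Compound 3 lies within the scatter of compound 2, while compound 1 stands at a lower number than compound 3, beyond the scatter. Compound 4 `CCN(CC)S(=O)(=O)c1ccc(S(=O)(=O)N2CCC[C@@H](C(=O)N3CCN(c4nc(C(C)C)no4)CC3)C2)cc1` differs from compound 3 at one place, diethylamino in place of isopropylamino on a sulfonyl sulfur with diethylamino in place of isopropylamino on a sulfonyl sulfur. Within the data shown here, the only measured step at a sulfonamide nitrogen is a 1.5-fold lower number from compound 2 to compound 3 (0.18 log units; within the scatter) for isopropyl in place of cyclopropyl, and it gives little guidance for a change this different. Compound 1 already carries diethylamino and gives 60 nM in this series, but it differs from compound 4 elsewhere in the structure, so its value cannot isolate this change. Among the measured compounds shown here, no measured pair does. The expectation in this assay is therefore for no step beyond the scatter, with a lean towards a lower number. The estimated step is a 1.7-fold lower number from compound 3 to compound 4 (0.22 log units; within the scatter) on this reading. Compound 4 is expected at 120 nM with an estimated range from 50 nM to 300 nM in this assay.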

Compound 4, half-maximal inhibitory concentration: 30 nM
Compound 4: middle estimate off by 4.0-fold (0.60 log units), on the high side, outside the stated range (below it).
By their numbers in this assay, from the lowest: compounds 4 and 1 (each within the scatter of the next); then compounds 3 and 2 (each within the scatter of the next).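

In this assay, the group on the sulfonyl sulfur turns out to matter: diethylamino in place of isopropylamino gives a 6.7-fold lower number from compound 3 to compound 4 (0.82 log units; beyond the scatter), and diethylamino in place of cyclopropylamino gives a 10-fold lower number from compound 2 to compound 4 (1.00 log units; beyond the scatter), whereas the earlier exchange between the two secondary groups stayed within the scatter. With diethylamino held constant, isopropyl in place of trifluoromethyl on an aromatic carbon gives a 2.0-fold lower number from compound 1 to compound 4 (0.30 log units; within the scatter), so this pair shows no separation between those two groups. Going from isopropylamino to diethylamino also takes the count of hydrogen-bond donors from one to zero, but nothing measured here explains the step.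

The compounds shown leave open whether the step follows the loss of the hydrogen on the sulfonamide nitrogen or the larger group, a question that dimethylamino, ethylamino or a piperidine on the same sulfur could help to separate. They also leave open whether trifluoromethyl and isopropyl would stay as close with isopropylamino on the sulfonyl sulfur, and how a longer chain such as dipropylamino would read in this assay.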